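This account rests on a few compounds, and the source may have more. Where it says the series, first, only, none or still open, it means among the compounds named here.

Two members of the series share a core that carries a 3,4-difluorophenyl group and a propyl-linked piperidine bearing an aryl group. Compound 1 `COCC1=C(C(=O)NCCCN2CCC(c3ccccc3C#N)CC2)[C@@H](c2ccc(F)c(F)c2)NC(=O)N1` gives 285 nM in an assay on LM cells with Alpha-1B adrenergic receptor (Homo sapiens) as the target; a higher number here means a weaker inhibitor, a lower number a stronger inhibitor. Compound 2 `O=C1NC(C(F)(F)F)=C(C(=O)NCCCN2CCC(c3ccc(F)cc3)CC2)[C@@H](c2ccc(F)c(F)c2)N1` gives 270 nM in this assay, and the two values sit within the scatter of each other, so neither is separated from the other. Compound 3 `COCC1=C(C(=O)NCCCN2CCC(c3ccc(F)cc3)CC2)[C@@H](c2ccc(F)c(F)c2)NC(=O)N1` has not yet been measured; it differs from compound 2 by methoxymethyl in place of trifluoromethyl on a double-bonded ring carbon. Going by the values given here, no step between measured compounds bears on this exchange, so no change beyond the scatter is expected for the move from compound 2 to compound 3 a 1.1-fold higher number from compound 2 to compound 3 (0.05 log units; within the scatter). Compound 3 is estimated at 300 nM, within 120 nM to 750 nM.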

Compound 3, inhibition constant: 41 nM
For compound 3 the middle estimate is 7.3-fold (0.86 log units) above the measured one; the whole stated range lies above it.
By their numbers in this assay, from the lowest: compound 3; then compounds 2 and 1 (each within the scatter of the next).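

In this assay, the double-bonded ring carbon is sensitive to its substituent: methoxymethyl in place of trifluoromethyl gives (a 6.6-fold lower number from compound 2 to compound 3 (0.82 log units; beyond the scatter)). With methoxymethyl held constant, the aryl group also matters: 4-fluorophenyl in place of 2-cyanophenyl on a saturated ring carbon gives (a 7.0-fold lower number from compound 1 to compound 3 (0.84 log units; beyond the scatter)). Nothing available explains either step.

As far as these compounds go, it remains open whether the oxygen of methoxymethyl is needed, which a plain ethyl group, a hydroxymethyl group or a longer ethoxymethyl chain at this carbon could test. From the compounds shown here alone, it is also open whether the aryl step carries over to the trifluoromethyl compounds.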